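The source may report more compounds than this note shows. Statements on the series, on what has been measured and on what is new or still open speak of the compounds shown alone.

Series notes. Compound 1 `NS(=O)(=O)NCCC1CCN(c2cc(-c3ccccc3)ncn2)CC1` carries an unsubstituted phenyl on the shared core. In a functional assay on M21 cells (Homo sapiens) for antiproliferative activity, read by sulforhodamine B assay, with a stated time of 48 h (a higher number here means a weaker inhibitor of growth, a lower number a stronger inhibitor of growth), compound 1 gives only a limit, > 100000 nM. Compound 2 `CC(C)(C)c1ccc(-c2cc(N3CCC(CCNS(N)(=O)=O)CC3)ncn2)cc1` adds a tert-butyl to that ring, and in this assay compound 2 gives 18400 nM. Compound 3 `NS(=O)(=O)NCCC1CCN(c2cc(-c3ccc(C(F)(F)F)cc3)ncn2)CC1` carries a trifluoromethyl instead, and in this assay compound 3 gives 34800 nM, the higher of the two numbers shown; the gap is a 1.9-fold higher number from compound 2 to compound 3 (0.28 log units; within the scatter), so compound 2 and compound 3 cannot be ordered. Against the parent the steps were an at least 5.4-fold lower number from compound 1 to compound 2 (0.73 log units; beyond the scatter) and an at least 2.8-fold lower number from compound 1 to compound 3 (0.45 log units; beyond the scatter). Both start from the limit of > 100000 nM in this assay, at which 1 of the 3 values shown sits, so their size is a floor only.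

Compound 4 `COC(=O)c1ccc(-c2cc(N3CCC(CCNS(N)(=O)=O)CC3)ncn2)cc1` differs from compound 3 by methoxycarbonyl in place of trifluoromethyl on an aromatic carbon. Among the measured compounds shown here, the only measured exchange of one group for another on that aromatic carbon is a 1.9-fold higher number from compound 2 to compound 3 (0.28 log units; within the scatter), within the scatter, and both groups tried there gave a number where the parent gave none; a methoxycarbonyl at that place has no precedent. The expectation for compound 4 is therefore a number near that of compound 3 with wide uncertainty, a step of a 1.1-fold higher number from compound 3 to compound 4 (0.06 log units; within the scatter). Compound 4 is estimated at 40000 nM, within 10000 nM to 150000 nM.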

Compound 4, concentration for 50% growth inhibition: 19600 nM
Estimate against measurement, compound 4: 2.0-fold (0.31 log units) above; low and high end bracket the measured number.
By their numbers in this assay, from the lowest: compounds 2, 4 and 3 (each within the scatter of the next). At a limit, above all of these: compound 1.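

In this assay, methoxycarbonyl is a third group on that aromatic carbon, and the steps of a 1.8-fold lower number from compound 3 to compound 4 (0.25 log units; within the scatter) and a 1.1-fold higher number from compound 2 to compound 4 (0.03 log units; within the scatter) leave compounds 2, 3 and 4 unordered. Among the compounds shown here, the exchange brings in a carbonyl and 2 hydrogen-bond acceptors where trifluoromethyl has 0, yet the step stays within the scatter, so this difference in the group has no readable consequence so far. All three groups on that carbon now give a number where compound 1 gives only a limit, with no compound among those shown going against this, and the newest step, an at least 5.1-fold lower number from compound 1 to compound 4 (0.70 log units; beyond the scatter), is a floor on its size, not a measure of it: the limit of > 100000 nM in this assay, at which 1 of the 4 values shown sits.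

On these data alone, what an amine, a carboxylic acid or a longer chain on that aromatic carbon would give remains open, as does whether any group there can separate from compounds 2, 3 and 4 by more than the scatter. Whether the gain over compound 1 depends on the group's identity, or only on something other than hydrogen standing at that carbon, also stays undecided.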